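Aryl exchange on an aromatic nitrogen: compound 3 to compound 4

This account rests on a few compounds, and the source may have more. Where it says the series, first, only, none or still open, it means among the compounds named here.

Measured so far in a functional assay on HCT-116 cells (Homo sapiens) for antiproliferative activity, read by MTT assay, with a stated time of 48 h; on this read-out lower numbers stand for stronger inhibition and higher numbers for weaker inhibition:
compound 1 `N#CC1=C(N)Oc2c(c3nc4ccccc4nc3c3ccccc23)C12C(=O)N(Cc1cnnn1-c1ccc(Br)cc1)c1ccccc12` gives > 50000 nM
compound 2 `N#CC1=C(N)Oc2c(c3nc4ccccc4nc3c3ccccc23)C12C(=O)N(Cc1cnnn1-c1cccc(S(N)(=O)=O)c1)c1ccccc12` gives 11300 nM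
compound 3 `N#CC1=C(N)Oc2c(N)cc3nc4ccccc4nc3c2C12C(=O)N(Cc1cnnn1-c1cccc(C(F)(F)F)c1)c1ccccc12` gives 18900 nM

The value of compound 1 is a limit of this assay, not a number (the limit of > 50000 nM in this assay, at which 1 of the 3 values shown sits). Among the two numbers, compound 3 stands highest, with compound 2 nearest and within the scatter of it. Compound 4 `COc1cc(-n2nncc2CN2C(=O)C3(C(C#N)=C(N)Oc4c(N)cc5nc6ccccc6nc5c43)c3ccccc32)c(OC)cc1Cl` is not yet measured; it differs from compound 3 as follows: 4-chloro-2,5-dimethoxyphenyl in place of 3-(trifluoromethyl)phenyl on an aromatic nitrogen. One measured step also exchanges the aryl on this aromatic nitrogen: an at least 4.4-fold lower number from compound 1 to compound 2 (0.64 log units; beyond the scatter). That step shows the aryl can move the number, yet the present exchange differs from it, so the account expects no change beyond the scatter, stated as a 1.2-fold lower number from compound 3 to compound 4 (0.07 log units; within the scatter). Compound 4 is therefore estimated at 16000 nM, between 5000 nM and 50000 nM.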

Compound 4, half-maximal inhibitory concentration: > 50000 nM
Compound 4: a limit, no number; the forecaster's own chance of this, stated with the estimate: 20%; middle value at least 3.1-fold (0.49 log units) from the limit.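

In this assay the value of compound 4 is a limit and not a number: the limit of > 50000 nM in this assay, at which 2 of the 4 values shown sit.

Even so, 4-chloro-2,5-dimethoxyphenyl in place of 3-(trifluoromethyl)phenyl gives an at least 2.6-fold higher number from compound 3 to compound 4 (0.42 log units; beyond the scatter). The earlier exchange on this aromatic nitrogen gave an at least 4.4-fold lower number from compound 1 to compound 2 (0.64 log units; beyond the scatter), whereas this one shows that an aryl exchange here can also raise the number, and does so on the core of compound 3.

The compounds shown do not separate the chlorine from the two methoxy groups. On these data alone, whether an aryl bearing an amine or a carboxylic acid would give a lower number on the core of compound 3 remains open.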